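Pyridyl Group in Place of Cyanophenyl on Shared Core

The compounds below may be only part of what the source reports. "The series", "measured", "known", "first", "only" and "open" are said of these compounds alone.

Compound 1, `CC1c2c(-c3ccncc3)c(-c3ccccc3C#N)nn2CC1(C)C`: 77000 nM in a functional assay on K562 cells (Homo sapiens) for cytotoxicity, with a stated time of 72 h; on this read-out lower numbers stand for stronger inhibition and higher numbers for weaker inhibition
Compound 3, `Cc1cccc(-c2nn3c(c2-c2ccncc2)C(C)C(C)(C)C3)c1C#N`: 92000 nM
Compound 2, `CC1(C)Cc2c(-c3ccncc3)c(-c3ccccc3C#N)nn2C1`: > 100000 nM, a limit of the assay

Compound 1 stands lowest of the two numbers shown; compound 3 is nearest, at a 1.2-fold higher number from compound 1 to compound 3 (0.08 log units; within the scatter). Compound 2 sits at the limit (the limit of > 100000 nM in this assay, at which 1 of the 3 values shown sits), so its step from compound 1 is an at least 1.2-fold higher number from compound 1 to compound 2 (0.11 log units; that floor lies within the scatter). Compound 4, `CCc1cccc(-c2nn3c(c2-c2ccncc2)C(C)C(C)(C)C3)n1`, differs from compound 1 by 6-ethylpyridin-2-yl in place of 2-cyanophenyl on an aromatic carbon. Neither measured step touches this place: one alters a saturated ring carbon, the other adds a methyl on an aromatic carbon, and both lie within the scatter. No step beyond the scatter is therefore expected in this assay for compound 4, whose estimated step is a 1.0-fold higher number from compound 1 to compound 4 (0.02 log units; within the scatter). Compound 4 is expected to give about 80000 nM, between 30000 nM and 200000 nM.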

Compound 4, half-maximal inhibitory concentration: > 100000 nM
Compound 4: only a limit was reported (the forecaster's own chance of this, stated with the estimate: 35%); at least 1.2-fold (0.09 log units) between middle value and limit.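

Swapping 2-cyanophenyl for 6-ethylpyridin-2-yl is the only change shown at this aromatic carbon, and in this assay it gives an at least 1.2-fold higher number from compound 1 to compound 4 (0.11 log units; that floor lies within the scatter). This shows no gain from the change at this position, and the nitrile is not the only group shown here. Compound 4 gives a limit rather than a number, so the full size of its step stays unknown: the limit of > 100000 nM in this assay, at which 2 of the 4 values shown sit.

The compounds shown leave open whether the pyridine nitrogen or the ethyl group matters more. They also leave open whether a longer chain in place of ethyl, an amine or a carboxylic acid at this carbon would give a clearly lower number.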